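From 4-methylphenyl to 4-chlorophenyl in a weak series

The compounds below may be only part of what the source reports. "The series", "measured", "known", "first", "only" and "open" are said of these compounds alone.

In a functional assay on NPC-TW01 cells (Homo sapiens) for inhibition, read by MTT assay, with a stated time of 72 h (on this read-out lower numbers stand for stronger inhibition of growth and higher numbers for weaker inhibition of growth), compound 1 `CN(C)/C=N/c1cc(-c2ccc(Cl)cc2)nn1-c1cccc(Cl)c1` gives 92700 nM. Compound 2 `Cc1ccc(-c2cc(/N=C/N(C)C)n(-c3ccc(Br)cc3)n2)cc1` reads > 100000 nM, which is a limit of the assay and not a number.

Compound 3 `CN(C)/C=N/c1cc(-c2ccc(Cl)cc2)nn1-c1ccc(Br)cc1` carries chloro in place of methyl on an aromatic carbon. The 4-chlorophenyl of compound 3 also occurs in compound 1, which gives 92700 nM. In this assay a small step towards stronger inhibition of growth is expected, perhaps none beyond the scatter: an at least 1.1-fold lower number from compound 2 to compound 3 (0.07 log units; that floor lies within the scatter). Compound 3 is estimated at 85000 nM, with an expected range of 40000 nM to 150000 nM.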

Compound 3, concentration for 50% growth inhibition: 60700 nM
Compound 3: middle estimate off by 1.4-fold (0.15 log units), on the high side; measured number inside the range.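

In this assay, 4-chlorophenyl in place of 4-methylphenyl gives an at least 1.6-fold lower number from compound 2 to compound 3 (0.21 log units; that floor lies within the scatter). That step is only a floor, because compound 2 reads as a limit of the assay and not a number: the limit of > 100000 nM in this assay, at which 1 of the 3 values shown sits. On the aromatic nitrogen, the other point of variation, the change gives a 1.5-fold lower number from compound 1 to compound 3 (0.18 log units; within the scatter), so no difference can be claimed there.

As far as these compounds go, the true size of the step from methyl to chloro remains open. So does the reading in this assay with an amine or a carboxylic acid on that aromatic carbon.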